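The source may hold more compounds than are shown below. What is called first, only, known or untested is meant among the compounds shown, and "the series" means these compounds.

Working notes on the series. For the measured compounds named here, compound 2 `COc1ccc(C(=O)Nc2cccc(-c3ccnc4c(NC(C)=O)cccc34)c2)cc1OC` gives the higher of the two numbers so far: in a functional assay on A375P cells (Homo sapiens) for antiproliferative activity, read by MTT assay, with a stated time of 48 h (on this read-out higher numbers stand for weaker inhibition and lower numbers for stronger inhibition), compound 2 gives 5300 nM, while compound 1 `Nc1cccc2c(-c3cccc(NC(=O)c4ccc5c(c4)OCCO5)c3)ccnc12` gives 860 nM, a gap beyond the scatter. Going by the values given here, compound 3 `CC(=O)Nc1cccc2c(-c3cccc(NC(=O)c4ccc(Cl)cc4C(F)(F)F)c3)ccnc12` differs from compound 2 by 4-chloro-2-(trifluoromethyl)phenyl in place of 3,4-dimethoxyphenyl on a carbonyl carbon; no step of this kind is known. On the shared core, a step toward a lower number in this assay is expected, of moderate size, a 2.9-fold lower number from compound 2 to compound 3 (0.47 log units; beyond the scatter). Compound 3 is estimated at 1800 nM, within 450 nM to 7000 nM.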

Compound 3, half-maximal inhibitory concentration: > 20000 nM
Compound 3 was reported as a limit (the forecaster's own chance of this, stated with the estimate: 5%); middle value at least 11-fold (1.04 log units) from the limit.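

On the carbonyl carbon whose other neighbour is the amide-type nitrogen, 4-chloro-2-(trifluoromethyl)phenyl in place of 3,4-dimethoxyphenyl gives an at least 3.7-fold higher number from compound 2 to compound 3 (0.57 log units; beyond the scatter) in this assay, so the group at this place is not interchangeable on the shared core. Compound 3 is reported only as a limit of the assay, not as a number: the limit of > 20000 nM in this assay, at which 1 of the 3 values shown sits.

As far as these compounds go, the full size of the step therefore stays unknown. The compounds shown change chlorine and trifluoromethyl together, so it remains open which of the two goes with the loss, and how a plain phenyl or a pyridyl would stand on this carbonyl carbon.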